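Changing the group on the amide-type nitrogen

This account rests on a few compounds, and the source may have more. Where it says the series, first, only, none or still open, it means among the compounds named here.

compound 1 `O=C(Nc1cccc([N+](=O)[O-])c1)N1CCN(S(=O)(=O)c2sccc2-c2ccccc2Oc2ccc(O)c(O)c2)CC1` gives 4500 nM
compound 2 `COc1ccc(Oc2ccccc2-c2ccsc2S(=O)(=O)N2CCN(C(=O)Nc3cccc([N+](=O)[O-])c3)CC2)cc1OC` gives > 50000 nM as a limit

Going by the values given here, in a functional assay on HL-60 cells (Homo sapiens) for inhibition, read by CCK-8 assay, with a stated time of 48 h (on this read-out lower numbers stand for stronger inhibition and higher numbers for weaker inhibition), compound 1 gives 4500 nM as the only true number so far. Compound 2 gives > 50000 nM as a limit of the assay and not a number. Among the compounds with values here, the only measured step is an at least 11-fold higher number from compound 1 to compound 2 (1.04 log units; beyond the scatter) and it is large, with 3,4-dimethoxyphenyl in place of 3,4-dihydroxyphenyl on an oxygen on an aromatic ring.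

Compound 3 `O=C(Nc1ccc(F)cc1)N1CCN(S(=O)(=O)c2sccc2-c2ccccc2Oc2ccc(O)c(O)c2)CC1` keeps the 3,4-dihydroxyphenyl of compound 1 and changes at another place, as 4-fluorophenyl in place of 3-nitrophenyl on an amide-type nitrogen shows, with 4-fluorophenyl in place of 3-nitrophenyl on an amide-type nitrogen. Within the data shown here, no measured step touches that place, so the data give no direction for this change. The large step of an at least 11-fold higher number from compound 1 to compound 2 (1.04 log units; beyond the scatter) bears on it only indirectly, since compound 3 keeps the group changed there. In this assay little or no step beyond the scatter is therefore expected, though with a wide margin. The estimated change is a 1.1-fold higher number from compound 1 to compound 3 (0.05 log units; within the scatter) in size. The expected value for compound 3 is 5000 nM within an estimated range from 1500 nM to 20000 nM on this read-out.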

Compound 3, half-maximal inhibitory concentration: 8100 nM
Compound 3: the middle estimate sits 1.6-fold (0.21 log units) below what was measured, within the range that was stated.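

In this assay, putting 4-fluorophenyl in place of 3-nitrophenyl on the amide-type nitrogen gives a 1.8-fold higher number from compound 1 to compound 3 (0.26 log units; within the scatter), and this step lies within the usual scatter, so the two compounds cannot be told apart. Going by these compounds alone, this is the first view of this place, and it shows that with the 3,4-dihydroxyphenyl kept, the nitro group can go and a true number remains, while the only large change so far is still the one at the 3,4-dihydroxyphenyl. Nothing shown gives a measured reason why these two rings behave alike at this place.

The pair changes two things at once, the group on the ring and where the name places it, so a 3-fluorophenyl or a 4-nitrophenyl would be needed to pull those two apart. The compounds shown also leave open whether an aromatic ring is needed on this nitrogen at all, and whether it tolerates something quite different, such as a cyclohexyl group, a plain alkyl chain, or a phenyl ring carrying a carboxylic acid or an amine.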